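A few compounds are considered here, and "the series" means these few. Any claim that something is new, unique, unknown or untested is made for them only; others in the source may bear on it.

Measured compounds in the series:
compound 1 `CC1=CC(=O)C(=C(C)C)C[C@@]2(O)[C@H](C)CC[C@@H]12`: 69.5%
compound 2 `CC1=CC(=O)O[C@@]2(CC(=O)C(C)C)[C@@H](C)CC[C@@H]12`: 73.4%
compound 3 `CC1=C2CC(=O)[C@@H](C)CC/C=C(\C)C[C@H]2OC1=O`: 65.4%

All three were run in a functional assay on PC-12 cells (Rattus norvegicus) for cytotoxicity, read by MTT assay, with a stated time of 24 h, tested at 1 uM; a lower number here means a weaker effect, a higher number a stronger effect of the compound at the concentration tested. Compound 2 gives the largest of the three numbers, yet compound 1 and compound 3 each lie within the usual scatter of it, so no order among the three is secure. Compound 4 `C=C(C)C(=O)C[C@@]12OC(=O)C=C(C)[C@@H]1CC[C@@H]2C` has not yet been measured. It differs from compound 2 in one place: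

1-methylethenyl in place of isopropyl on a carbonyl carbon

Going by the values given here, no pair of measured compounds shows this change, so its effect is untested. A modest step, upward or none beyond the scatter, is expected. For compound 4 the estimated value in this assay is 76%, with a range of 60% to 90%. The step this estimate implies, a number 2.6 percentage points higher from compound 2 to compound 4 (within the scatter), is an expectation only.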

Compound 4, a percentage reported as activity, at one concentration (the size of the read-out at that concentration, not a potency): 69.3%
The estimate for compound 4 lay 6.7 percentage points above the measured number, and the stated range covers the measured number.
By their numbers in this assay, from the lowest: compounds 3, 4, 1 and 2 (each within the scatter of the next).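

In this assay, 1-methylethenyl in place of isopropyl on a carbonyl carbon gives a number 4.1 percentage points lower from compound 2 to compound 4 (within the scatter), the first step read at this position. The double bond outside aromatic rings that enters with this change therefore brings no difference beyond the scatter in this read-out. No evidence on the cause of this result is available.

Going by these compounds, whether an amine, a carboxylic acid or a longer chain on this carbonyl carbon would move the read-out beyond the scatter remains open. This read-out also shows only the size of the effect at the concentration tested.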